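Oxamic versus malonamic acid on the shared core

This account rests on a few compounds, and the source may have more. Where it says the series, first, only, none or still open, it means among the compounds named here.

Measured so far:
compound 1, `Cc1cc2cc(NC(=O)C(=O)O)ccc2n1Cc1ccc(O)c(C(C)C)c1`, 230 nM
compound 2, `Cc1cc2c(NC(=O)CC(=O)O)cccc2n1Cc1ccc(O)c(C(C)C)c1`, 5200 nM

In an assay on isolated protein for displacement of a labelled ligand from thyroid hormone receptor alpha (Homo sapiens), with a stated time of 3 h (on this read-out lower numbers stand for stronger inhibition and higher numbers for weaker inhibition), compound 2 stands highest of the two numbers recorded. For the measured compounds named here, the nearest value belongs to compound 1, whose number is the lower one by a margin beyond the scatter; the two compounds differ in more than one place, so the pair shows only that the two values lie far apart, not which part of the difference carries it.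

Compound 3, `Cc1cc2c(NC(=O)C(=O)O)cccc2n1Cc1ccc(O)c(C(C)C)c1`, is not yet measured. It differs from compound 2 in one place: carboxy in place of carboxymethyl on a carbonyl carbon. Compound 1 carries the same carboxycarbonyl amide, on a different position of the core, and in this assay compound 1 gives 230 nM. On that ground a move to a lower number is expected for compound 3, as the step of an 8.7-fold lower number from compound 2 to compound 3 (0.94 log units; beyond the scatter), with the attachment position left as an open question. The estimate for compound 3 in this assay is 600 nM, within a range from 150 nM to 3000 nM.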

Compound 3, half-maximal inhibitory concentration: 230 nM
Estimate against measurement, compound 3: 2.6-fold (0.42 log units) above, and the stated range covers the measured number.
By their numbers in this assay, from the lowest: compounds 1 and 3 (each within the scatter of the next); then compound 2.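

Carboxy in place of carboxymethyl on a carbonyl carbon, with the amide-type nitrogen kept, is the one change in the series so far that can be read alone: in this assay it gives a 23-fold lower number from compound 2 to compound 3 (1.35 log units; beyond the scatter) and so ties a large gap to this single change at this point of the shared core. With the carboxycarbonyl amide present at both points of attachment, compound 1 gives 230 nM and compound 3 gives 230 nM and the two values show no separation in this read-out, something the earlier pair could not show. Nothing at hand bears on why carboxy gives the lower number here.

Whether the same step holds at the attachment point of compound 1 stays open, since carboxymethyl on the carbonyl carbon is shown at only one point of the shared core. Also open, going by these compounds, is how the series responds to a longer chain such as carboxyethyl on that carbonyl carbon, or to an ester or a primary amide in place of the carboxylic acid.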